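Benzyl Change on a Diamine Chain, Growth Inhibition Expected

The source may report more compounds than this note shows. Statements on the series, on what has been measured and on what is new or still open speak of the compounds shown alone.

Compound 1 `O=S(=O)(NCCCNCc1ccccc1Cl)c1cc(C(F)(F)F)cc(C(F)(F)F)c1`: in a functional assay on BXPC-3 cells (Homo sapiens) for inhibition, read by MTT assay, with a stated time of 72 h (on this read-out lower numbers stand for stronger inhibition of growth and higher numbers for weaker inhibition of growth), compound 1 gives 11000 nM.
Compound 2 `O=S(=O)(NCCCNCc1ccc(Cl)c(C(F)(F)F)c1)c1cc(C(F)(F)F)cc(C(F)(F)F)c1`: in this assay compound 2 gives 7800 nM.

Among the two measured numbers, compound 1 stands at the highest, and its nearest neighbour is compound 2, separated by a 1.4-fold lower number from compound 1 to compound 2 (0.15 log units; within the scatter). The step from compound 1 to compound 2 exchanges 4-chloro-3-(trifluoromethyl)phenyl for 2-chlorophenyl on a saturated chain carbon bound to an amine nitrogen, and it stays within the scatter.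

Compound 3 `O=S(=O)(NCCCNCc1ccc(C(F)(F)F)cc1)c1cc(C(F)(F)F)cc(C(F)(F)F)c1` has not been measured in this assay. It differs from compound 1 by 4-(trifluoromethyl)phenyl in place of 2-chlorophenyl on a saturated chain carbon bound to an amine nitrogen. For the measured compounds named here, the only measured step that bears on this change is the one from compound 1 to compound 2, which also swaps the aryl group at the same place and produced no movement beyond the scatter. On that basis compound 3 is expected to sit close to compound 1, with an estimated step of a 1.2-fold lower number from compound 1 to compound 3 (0.09 log units; within the scatter), in no clear direction. The estimated value for compound 3 in this assay is 9000 nM, with a range from 4000 nM to 20000 nM.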

Compound 3, concentration for 50% growth inhibition: 1700 nM
Estimate against measurement, compound 3: 5.3-fold (0.72 log units) above, outside the stated range (below it).
By their numbers in this assay, from the lowest: compound 3; then compounds 2 and 1 (each within the scatter of the next).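

In this assay, for the compounds shown here, the aryl group on a saturated chain carbon bound to an amine nitrogen proves able to move the number: 4-(trifluoromethyl)phenyl in place of 2-chlorophenyl gives a 6.5-fold lower number from compound 1 to compound 3 (0.81 log units; beyond the scatter) and is the first step beyond the scatter. Placing the same group where compound 2 has 4-chloro-3-(trifluoromethyl)phenyl gives a 4.6-fold lower number from compound 2 to compound 3 (0.66 log units; beyond the scatter) and sets compound 3 apart from both earlier compounds, while compound 2, which also carries a trifluoromethyl group on this ring, stays within the scatter of compound 1, so among these three compounds a trifluoromethyl group on the ring does not by itself go with the lower number. Nothing available explains why 4-(trifluoromethyl)phenyl stands apart from the other two aryl groups.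

The compounds shown leave open whether the lower number follows the trifluoromethyl group at the 4-position alone or the absence of chlorine, and plain phenyl or 4-chlorophenyl at this place would separate the two. They also leave open whether the step would hold on a longer chain, or with an amide in place of the amine nitrogen.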